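The source may report more compounds than this note shows. Statements on the series, on what has been measured and on what is new or still open speak of the compounds shown alone.

Compound 2, `Cc1ccc(NC(=O)Nc2cc(C)nc3ccccc23)cc1`, and compound 3, `Cc1cc(NC(=O)Nc2ccc(Cl)cc2)c2ccccc2n1`, share a core that differs in one group: chloro in place of methyl on an aromatic carbon. In an ADME assay on Raji cells (Homo sapiens) for cytotoxicity, with a stated time of 72 h (a higher number here means that more compound is needed for the effect, a lower number that less compound is needed), compound 2 gives > 25000 nM, which is a limit of the assay and not a number. Compound 3 likewise stops at a limit in this assay, giving > 25000 nM. Compound 1, `Cc1cc(NC(=O)Nc2ccc(C)c(Cl)c2)c2ccccc2n1`, arises from compound 2 by chloro in place of hydrogen on an aromatic carbon. In this assay compound 1 gives > 25000 nM, again a limit rather than a number. The step that the two limits leave unreadable from compound 2 to compound 1 therefore cannot be sized, because of the limit of > 25000 nM in this assay, at which 3 of the 3 values shown sit. Compound 4, `Cc1cc(NC(=O)Nc2ccc(Cl)cc2Cl)c2ccccc2n1`, is not yet measured and arises from compound 3 by chloro in place of hydrogen on an aromatic carbon. The surroundings differ from those of the earlier change, which sat ortho to a methyl group and meta to a large group, whereas here the chloro enters ortho to a large group and meta to a chloro group, so it is the same kind of change rather than the same. Beside the unreadable earlier step, the step from compound 3 to compound 4 is expected to be a step that the limit leaves unreadable from compound 3 to compound 4, because of the limit of > 25000 nM in this assay, at which 3 of the 3 values shown sit. Compound 4 is thus expected to give about 30000 nM in this assay.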

Compound 4, half-maximal effective concentration: > 25000 nM
Compound 4: no number, only a limit; the forecaster's own chance of this, stated with the estimate: 80%; the middle value does not contradict the limit.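

No size can be read for the step between compound 3 and compound 4 in this assay, because both stop at a limit of the assay and give no number: the limit of > 25000 nM in this assay, at which 4 of the 4 values shown sit.

The compounds shown leave open what concentration any of them would need for the effect in this assay, and so whether any of these changes alters it.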